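The compounds below may be only part of what the source reports. "The series", "measured", "known", "first", "only" and "open" are said of these compounds alone.

Measured so far in an assay on HEK-293T cells for inhibition of diacylglycerol lipase-alpha (Homo sapiens), read by colorimetric assay; a lower number here means a stronger inhibitor, a higher number a weaker inhibitor:
- compound 1 `O=C(CCCCCc1ccccc1)c1nc2ccccc2s1`: compound 1 gives > 10000 nM
- compound 2 `O=C(CCCCCc1ccccc1)c1nc2ncccc2[nH]1`: compound 2 gives 1230 nM
- compound 3 `O=C(CCCCCCc1ccccc1)c1nc(C(F)(F)F)co1`: compound 3 gives 214 nM

The value of compound 1 is a limit of this assay, not a number (the limit of > 10000 nM in this assay, at which 1 of the 3 values shown sits). Of the two numbers shown, compound 3 has the lowest; the nearest is compound 2, whose number is higher by a gap that lies beyond the scatter. Going by the values given here, no pair of these three differs in a single place, so no step can be measured between them.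

The next compound, compound 4 `CNC(=O)c1coc(C(=O)CCCCCCc2ccccc2)n1`, is not yet measured in this assay. It differs from compound 3 in one place: methylcarbamoyl in place of trifluoromethyl on an aromatic carbon. Where the trifluoromethyl sat on the aromatic carbon of the five-membered aromatic ring with 1 nitrogen and 1 oxygen, a methylcarbamoyl now stands, bringing one hydrogen-bond donor and one acceptor where there were none.

Among the compounds with values here, no measured step informs this change, so the expectation is a modest step, most likely none beyond the scatter or a slight weakening: the step from compound 3 to compound 4 is expected to be a 1.5-fold higher number from compound 3 to compound 4 (0.17 log units; within the scatter). Compound 4 is expected to give about 320 nM in this assay, within 80 nM to 1500 nM.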

Compound 4, half-maximal inhibitory concentration: > 10000 nM
Compound 4 gave a limit, no number (the forecaster's own chance of this, stated with the estimate: 5%); at least 31-fold (1.49 log units) between middle value and limit.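

In this assay, going by these compounds alone, the aromatic carbon next to the ring nitrogen proves sensitive to the identity of its substituent, even though the entering and leaving groups both count 4 heavy atoms: methylcarbamoyl in place of trifluoromethyl gives an at least 46-fold higher number from compound 3 to compound 4 (1.66 log units; beyond the scatter), the first single-place step and a large one. Compound 4 stands at a limit of the assay, > 10000 nM, and this is not a number. Only a lower bound on the step can therefore be read, and its full size remains unknown, with compound 4 now sharing that limit with compound 1: the limit of > 10000 nM in this assay, at which 2 of the 4 values shown sit.

This single pair cannot separate the effect of removing trifluoromethyl from that of introducing the amide hydrogen or the carbonyl, and no cause for the loss can be assigned from it. From the compounds shown here alone, a methyl ester, a nitrile, a dimethylcarbamoyl group or a plain methyl on the same aromatic carbon would help to divide these contributions, and it remains open whether any group other than trifluoromethyl keeps a measurable value at this position.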